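A few compounds are considered here, and "the series" means these few. Any claim that something is new, unique, unknown or untested is made for them only; others in the source may bear on it.

Compound 3, `CC(C(=O)N1CCN(c2ccccc2F)CC1)N1C(=O)CCC1=O`, carries a 2-fluorophenyl group on the ring nitrogen of its shared core. In a functional assay on the whole organism (strain Swiss) with Mus musculus as the target, in the maximal electroshock model, with a stated time of 0.5 h, at a dose of 300 mg/kg by the intraperitoneal route (on this read-out higher numbers stand for a stronger effect at the one dose given and lower numbers for a weaker effect), compound 3 gives 50%, level with compound 2, `CC(C(=O)N1CCN(c2ccc(F)cc2)CC1)N1C(=O)CCC1=O`, which gives 50%, so the two sit together at the lowest of the three numbers. Compound 1, `CC(C(=O)N1CCN(c2cccc(Cl)c2)CC1)N1C(=O)CCC1=O`, with 3-chlorophenyl in that place, gives 100%. Compound 4, `CC(C(=O)N1CCN(c2cccc(F)c2)CC1)N1C(=O)CCC1=O`, differs from compound 3 by 3-fluorophenyl in place of 2-fluorophenyl on an amine nitrogen in a ring. The steps of a number 50 percentage points lower from compound 1 to compound 3 (beyond the scatter) and a number 50 percentage points lower from compound 1 to compound 2 (beyond the scatter) show that leaving a 3-substituted phenyl costs much, while no change at the digits printed from compound 2 to compound 3 (within the scatter) shows the two fluoro positions without difference. A rise is therefore expected for compound 4, about a number 25 percentage points higher from compound 3 to compound 4 (beyond the scatter), though a 3-fluoro group has not been measured. Compound 4 is estimated at 75%, between 40% and 100%.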

Compound 4, a percentage reported as activity, at one dose (the size of the read-out at that dose, not a potency): 50%
For compound 4 the middle estimate is 25 percentage points above the measured one, and the stated range covers the measured number.
By their numbers in this assay, from the lowest: compounds 2, 3 and 4 (each within the scatter of the next); then compound 1.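

Moving the fluoro group around the phenyl ring changes nothing in this assay: the steps are no change at the digits printed from compound 3 to compound 4 (within the scatter) and no change at the digits printed from compound 2 to compound 4 (within the scatter), so compounds 2, 3 and 4 stand level. With the ring place held fixed, the halogen alone gives a number 50 percentage points lower from compound 1 to compound 4 (beyond the scatter), so the 3-position by itself does not bring the higher number of compound 1; the change from chloro to fluoro does. Nothing available explains this difference.

As far as these compounds go, whether a 3-bromophenyl or a 3-methylphenyl group would stand with compound 1 or with compound 4 stays open. So does how a plain phenyl group would compare with them.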